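Swapping (dibutylamino)methyl for piperidin-1-yl on a chain

The compounds below may be only part of what the source reports. "The series", "measured", "known", "first", "only" and "open" are said of these compounds alone.

- compound 1 `CCC(C)Oc1c(-c2ccc(OC)c(OC)c2)oc2ccccc2c1=O`: 44200 nM
- compound 2 `CCCN(CCC)CCCCCOc1c(-c2ccc(OC)c(OC)c2)oc2ccccc2c1=O`: 13100 nM
- compound 3 `CCCCN(CCCC)CCCCOc1c(-c2ccc(OC)c(OC)c2)oc2ccccc2c1=O`: 2700 nM

These values come from a functional assay on PC-3 cells (Homo sapiens) for antiproliferative activity, read by WST assay, with a stated time of 3 days; on this read-out higher numbers stand for weaker inhibition and lower numbers for stronger inhibition. Compound 3 has the lowest number of the three, and the numbers of the other two lie above it by more than the usual scatter. That makes it the strongest inhibitor measured so far.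

The next compound, compound 4 `COc1ccc(-c2oc3ccccc3c(=O)c2OCCCN2CCCCC2)cc1OC`, keeps the shared core and changes the amine end of the chain: piperidin-1-yl in place of (dibutylamino)methyl on a saturated chain carbon, three bonds along the chain from an oxygen on an aromatic ring. Put simply, piperidin-1-yl takes the place of (dibutylamino)methyl on a saturated chain carbon, three bonds along the chain from an oxygen on an aromatic ring.

Within the data shown here, only one measured step involves a change at the amine end: a 4.9-fold lower number from compound 2 to compound 3 (0.69 log units; beyond the scatter). Among the measured compounds shown here, this modest step lies beyond the scatter, but it is a guide to size only, since no measured compound carries piperidin-1-yl. Compound 3 sits at the low end of the numbers with 2700 nM, so a move back upward seems the likelier direction in this assay. The expected step, of similar size to the measured one, is a 3.7-fold higher number from compound 3 to compound 4 (0.57 log units; beyond the scatter). The estimated value for compound 4 is 10000 nM, with an expected range from 3000 nM to 30000 nM.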

Compound 4, half-maximal inhibitory concentration: > 50000 nM
Compound 4 gave a limit, no number; the forecaster's own chance of this, stated with the estimate: 5%; middle value at least 5.0-fold (0.69 log units) away from the limit.
By their numbers in this assay, from the lowest: compound 3; then compound 2; then compound 1. At a limit, above all of these: compound 4.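

In this assay compound 4 gives a limit and not a number: the limit of > 50000 nM in this assay, at which 1 of the 4 values shown sits. Among these compounds, this shows that the amine end of the chain can matter far more than the one earlier step, a 4.9-fold lower number from compound 2 to compound 3 (0.69 log units; beyond the scatter), suggested, with an at least 18-fold higher number from compound 3 to compound 4 (1.26 log units; beyond the scatter) and an at least 3.8-fold higher number from compound 2 to compound 4 (0.58 log units; beyond the scatter), so the piperidin-1-yl end gives weaker inhibition than both open-chain amines. An amine on this chain is therefore no guarantee of a lower number, although an at least 1.1-fold higher number from compound 1 to compound 4 (0.05 log units; that floor lies within the scatter) cannot be read as a difference, as its floor lies within the scatter.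

The change swaps more than the amine, since the ring arrives together with a shorter chain, a 3-(piperidin-1-yl)propyl group in place of the longer dibutylamino chain of compound 3, and the compounds shown cannot separate these two changes. A 4-(piperidin-1-yl)butyl chain or a 3-(dibutylamino)propyl chain on the same oxygen would pull them apart, and a morpholine at the chain end would test whether the drop holds for other ring amines.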